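Replacing the amide on the oxazole with a methylsulfanyl group

The compounds below may be only part of what the source reports. "The series", "measured", "known", "first", "only" and "open" are said of these compounds alone.

Measured so far:
compound 1, `Cc1cccc(-c2cnc(C(=O)CCCCCCc3ccccc3)o2)n1`: 3.3 nM
compound 2, `CNC(=O)c1cnc(C(=O)CCCCCCc2ccccc2)o1`: 7 nM

In an assay (Rattus norvegicus) for inhibition of Fatty-acid amide hydrolase 1 (Homo sapiens) (a lower number here means a stronger inhibitor, a higher number a weaker inhibitor), compound 2 gives 7 nM, the higher of the two numbers; compound 1 gives 3.3 nM. Within the data shown here, the one measured step, a 2.1-fold higher number from compound 1 to compound 2 (0.33 log units; beyond the scatter), shows a modest loss when the aromatic group is exchanged for the small amide. Compound 3, `CSc1cnc(C(=O)CCCCCCc2ccccc2)o1`, carries the change (methylsulfanyl in place of methylcarbamoyl on an aromatic carbon). Among the measured compounds shown here, no measured step covers this exchange, so the expectation leans on the single step alone and stays loose. For compound 3 a further modest weakening is expected, a 2.1-fold higher number from compound 2 to compound 3 (0.33 log units; beyond the scatter), giving an estimated 15 nM with a range from 5 nM to 50 nM.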

Compound 3, inhibition constant: 25 nM
Beside the measured number, compound 3's estimate is 1.7-fold (0.22 log units) below it, and the stated range covers the measured number.
By their numbers in this assay, from the lowest: compound 1; then compound 2; then compound 3.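

Exchanging methylcarbamoyl for methylsulfanyl on this aromatic carbon gives a 3.6-fold higher number from compound 2 to compound 3 (0.55 log units; beyond the scatter), and exchanging 6-methylpyridin-2-yl for methylsulfanyl gives a 7.6-fold higher number from compound 1 to compound 3 (0.88 log units; beyond the scatter). Compound 3 is therefore the weakest inhibitor of the three, so the group at this position clearly affects inhibition, although all three numbers stay in the same low range. Nothing measured here explains the loss, including whether it is linked to losing the amide's hydrogen-bond donor. Still open, as far as these compounds go, is how a primary amine or a carboxylic acid would behave at this position. A longer sulfur-linked chain, such as ethylsulfanyl, also remains untested among the compounds shown.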